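Adding a Second Chlorine to the Best-Performing Phenyl Ring

The source may report more compounds than this note shows. Statements on the series, on what has been measured and on what is new or still open speak of the compounds shown alone.

Compounds measured so far:
- compound 1, `O=C(COCc1ccccc1)N1CCN(c2ccccc2Cl)CC1`, gives 1100 nM
- compound 2, `O=C(COCc1ccccc1)N1CCN(c2cccc(Cl)c2)CC1`, gives 6700 nM
- compound 3, `O=C(COCc1ccccc1)N1CCN(c2ccc(Cl)cc2)CC1`, gives 350 nM

All three share one core and differ only in where a single chlorine sits on the phenyl ring. In a functional assay on HEK293 cells for positive allosteric modulation of metabotropic glutamate receptor 5 (Homo sapiens), read by FLIPR and calcium flux (on this read-out lower numbers stand for an effect already at smaller amounts and higher numbers for an effect only at larger amounts of compound), compound 3 gives the lowest number of the three: the step of a 3.1-fold lower number from compound 1 to compound 3 (0.50 log units; beyond the scatter) and the step of a 19-fold lower number from compound 2 to compound 3 (1.28 log units; beyond the scatter) both lie beyond the scatter, so compound 3 stands clearly apart.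

Compound 4, `O=C(COCc1ccccc1)N1CCN(c2ccc(Cl)cc2Cl)CC1`, keeps everything in compound 3 and adds one more chlorine: chloro in place of hydrogen on an aromatic carbon. Among the compounds with values here, no measured pair shows this exact addition. The nearest guide is the step of a 3.1-fold lower number from compound 1 to compound 3 (0.50 log units; beyond the scatter), which compares a chlorine placed as in compound 1 with a chlorine placed as in compound 3 when only one is present. That step suggests the new chlorine, on its own, is the less favourable position, but it does not tell how two chlorines act together. A modest rise in the number, or none beyond the scatter, is therefore the expectation.

Compound 4 is estimated at 550 nM, within 200 nM to 1600 nM, an expected step of a 1.6-fold higher number from compound 3 to compound 4 (0.20 log units; within the scatter).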

Compound 4, half-maximal effective concentration: 1000 nM
Compound 4: the middle estimate sits 1.8-fold (0.26 log units) below what was measured; the measured number falls inside the stated range.
By their numbers in this assay, from the lowest: compound 3; then compounds 4 and 1 (each within the scatter of the next); then compound 2.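

In this assay, going from 4-chlorophenyl to 2,4-dichlorophenyl, which puts the new chloro ortho to a large group and meta to a chloro group, does not lower the number further: the step is a 2.9-fold higher number from compound 3 to compound 4 (0.46 log units; beyond the scatter), so with this position filled the compound loses ground to the one with a single chlorine. Adding a chloro to compound 1 gives a different picture, since the step of a 1.1-fold lower number from compound 1 to compound 4 (0.04 log units; within the scatter) shows that the two compounds cannot be told apart, while the step of a 6.7-fold lower number from compound 2 to compound 4 (0.83 log units; beyond the scatter) shows that the 2,4-dichlorophenyl compound still keeps well ahead of the 3-chlorophenyl one. So the effect of a second chlorine depends on which chlorine is already present, although nothing available here explains why this is so.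

Going by these compounds, whether a fluoro, a methyl or a methoxy group in this same place would cost as much as the chloro remains open. It is also open whether the pattern among these four compounds would hold if the other end of the shared core were changed, for example by adding a nitrile there.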